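Methoxy on the fused ring of compound 1

A few compounds are considered here, and "the series" means these few. Any claim that something is new, unique, unknown or untested is made for them only; others in the source may bear on it.

For the measured compounds named here, compound 1 `CCn1c(=O)/c(=C2\Sc3ccccc3N2C)s/c1=C\c1ccncc1Nc1ccccc1Cl` gives 780 nM in a functional assay on PC-3 cells (Homo sapiens) for inhibition (on this read-out higher numbers stand for weaker inhibition and lower numbers for stronger inhibition), the lower of the two numbers measured so far. Compound 2 `CCn1c(=O)/c(=C2\Sc3ccccc3N2C)s/c1=C\c1ccncc1Nc1cc(C)ccc1C` gives 2000 nM in this assay, the step being a 2.6-fold higher number from compound 1 to compound 2 (0.41 log units; beyond the scatter). Compound 3 `CCn1c(=O)/c(=C2\Sc3ccc(OC)cc3N2C)s/c1=C\c1ccncc1Nc1ccccc1Cl` differs from compound 1 by methoxy in place of hydrogen on an aromatic carbon. Going by the values given here, the one measured step concerns the group on the nitrogen, not the fused ring, so no measured step bears on this change, and there is no basis for expecting a shift beyond the scatter. The expected step is a 1.0-fold higher number from compound 1 to compound 3 (0.01 log units; within the scatter). For compound 3 the estimate in this assay is 800 nM, with a range from 300 nM to 2500 nM.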

Compound 3, half-maximal inhibitory concentration: 760 nM
Estimate against measurement, compound 3: 1.1-fold (0.02 log units) above, within the range that was stated.
By their numbers in this assay, from the lowest: compounds 3 and 1 (each within the scatter of the next); then compound 2.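

For the compounds shown here, with methoxy in place of hydrogen on an aromatic carbon of the fused ring system, the step in this assay is a 1.0-fold lower number from compound 1 to compound 3 (0.01 log units; within the scatter) and this gives a first reading on that ring. The earlier step concerned only the group on the nitrogen, whereas this position accepts methoxy without a shift beyond the scatter. No evidence is available that bears on this result.

On these data alone, whether an amine, a carboxylic acid or a longer alkoxy chain on this carbon would read the same remains open. So does whether methoxy would read the same alongside the 2,5-dimethylphenyl group of compound 2.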